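Compound 2 to compound 4: a ring contraction with chlorine

The source may report more compounds than this note shows. Statements on the series, on what has been measured and on what is new or still open speak of the compounds shown alone.

Of the compounds shown here, three sharing the same aryl-piperazine core have been measured in a functional assay on the whole organism for antagonist activity, with Rattus norvegicus as the target; on this read-out lower numbers stand for an effect already at smaller amounts and higher numbers for an effect only at larger amounts of compound. Compound 1 `c1ccc2c(c1)CC(CCCN1CCN(c3cccc4c3OCCO4)CC1)C2` gives 0.47 mg/kg, compound 2 `C1=C(CCN2CCN(c3cccc4c3OCCO4)CC2)c2ccccc2C1` gives 0.45 mg/kg, and compound 3 `C1=C(CCN2CCN(c3cccc4c3OCCO4)CC2)c2ccccc2CC1` gives 0.4 mg/kg. Compound 2 holds the second highest of the three numbers, but its gap to compound 1 and its gap to compound 3 both lie within the scatter of repeated measurements, so the three read as one level. Compound 4 `Clc1cccc2c1CC2CCN1CCN(c2cccc3c2OCCO3)CC1` has not yet been measured in this assay. It arises from compound 2 through the change (a group of 9 heavy atoms (8 carbon, 1 chlorine; one four-membered non-aromatic ring of carbon only, one six-membered aromatic ring of carbon only) in place of a group of 9 heavy atoms (9 carbon; one five-membered non-aromatic ring of carbon only, one six-membered aromatic ring of carbon only), on a saturated chain carbon, two bonds along the chain from an amine nitrogen in a ring). Among the measured compounds shown here, no measured pair in this set carries a comparable change, so nothing here points to a direction. The author therefore expects compound 4 to sit close to compound 2 in this assay, with the step of a 1.3-fold higher number from compound 2 to compound 4 (0.12 log units; within the scatter) estimated as small, and an expected value of 0.6 mg/kg, ranging from 0.25 mg/kg to 1.5 mg/kg.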

Compound 4, dose for 50% inhibition: 1.13 mg/kg
Estimate against measurement, compound 4: 1.9-fold (0.27 log units) below, and the stated range covers the measured number.
By their numbers in this assay, from the lowest: compounds 3, 2 and 1 (each within the scatter of the next); then compound 4.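

In this assay, among the compounds shown here, the change shows a 2.5-fold higher number from compound 2 to compound 4 (0.40 log units; beyond the scatter) and so marks this place, on a saturated chain carbon, two bonds along the chain from an amine nitrogen in a ring, as one where the group matters, which the earlier compounds could not show. No measured evidence accounts for this step. The step brings the four-membered non-aromatic ring and the chlorine together, so the compounds shown do not separate the two. On these data alone, whether a fluorine or a methyl group in place of the chlorine would give a number closer to that of compound 2 remains open.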